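The source may report more compounds than this note shows. Statements on the series, on what has been measured and on what is new or still open speak of the compounds shown alone.

Results in a functional assay on cells (Platelet, Homo sapiens) for inhibition; on this read-out lower numbers stand for stronger inhibition and higher numbers for weaker inhibition:

Compound 1 `CCCOC(=O)c1ccc(-c2nn(Cc3ccccc3)c3ccccc23)cc1`: > 10000 nM, a limit of the assay.
Compound 2 `CC(C)OC(=O)c1ccc(-c2nn(Cc3ccccc3)c3ccccc23)cc1`: > 10000 nM, a limit of the assay.
Compound 3 `CNC(=O)c1ccc(-c2nn(Cc3ccccc3)c3ccccc23)cc1`: > 10000 nM, a limit of the assay.

Compound 3 has no number of its own, and it stands at the limit of > 10000 nM in this assay, at which 3 of the 3 values shown sit. Compound 4 `CCNC(=O)c1ccc(-c2nn(Cc3ccccc3)c3ccccc23)cc1` differs from it by methyl in place of hydrogen on a saturated chain carbon bound to an amide-type nitrogen.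

The measured steps offer little guidance. The nearest is a step that the two limits leave unreadable from compound 2 to compound 3, and a step that the two limits leave unreadable from compound 1 to compound 3 and a step that the two limits leave unreadable from compound 1 to compound 2 are no more informative, so none of them gives a size. For the measured compounds named here, no measured step changes this chain on the amide-type nitrogen. With compound 3 at > 10000 nM, a limit, no step beyond the scatter is expected in this assay, in either direction, although a small chance of a measurable value remains. The expected outcome is a number no higher from compound 3 to compound 4 (the limit leaves the size open). For compound 4 the estimate is 10000 nM, with an expected range of 2500 nM to 30000 nM.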

Compound 4, half-maximal inhibitory concentration: > 10000 nM
Compound 4: only a limit was reported (the forecaster's own chance of this, stated with the estimate: 75%); the middle value lies on the limit itself.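

In this assay compound 4 gives > 10000 nM, which is a limit of the assay, so its steps from compound 1, compound 2 and compound 3 cannot be read: the limit of > 10000 nM in this assay, at which 4 of the 4 values shown sit. The compounds shown leave open whether any of these changes on the carbonyl carbon alters inhibition.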